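Propylamino in Place of Amino on Compound 3

The source may hold more compounds than are shown below. What is called first, only, known or untested is meant among the compounds shown, and "the series" means these compounds.

Compound 1 `Nc1nc(Cl)c(-c2ncco2)c(N[C@@H]2C[C@H](CO)[C@@H](O)[C@H]2O)n1` and compound 2 `Nc1ncc(-c2nc3ccccc3s2)c(N[C@@H]2C[C@H](CO)[C@@H](O)[C@H]2O)n1` each carry the same cyclopentane-diol substituent on an aminopyrimidine core. In an ADME assay on cells (Homo sapiens) for cytotoxicity, read by polymerase chain reaction, with a stated time of 3 days (on this read-out higher numbers stand for lower toxicity in this test and lower numbers for higher toxicity in this test), compound 1 gives > 25000 nM, a limit of the test rather than a number. In this assay compound 2 likewise gives > 25000 nM, again a limit. Compound 3 `Cc1nc(N)nc(N[C@@H]2C[C@H](CO)[C@@H](O)[C@H]2O)c1-c1nc2ccccc2s1` differs from compound 2 by a methyl in place of hydrogen on an aromatic carbon, and in this assay compound 3 gives 4000 nM. That change produced an at least 6.2-fold lower number from compound 2 to compound 3 (0.79 log units; beyond the scatter). Among the measured compounds shown here, compound 3 thus holds the only number in the set, set against (the limit of > 25000 nM in this assay, at which 2 of the 3 values shown sit).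

Compound 4 `CCCNc1nc(C)c(-c2nc3ccccc3s2)c(N[C@@H]2C[C@H](CO)[C@@H](O)[C@H]2O)n1` arises from compound 3 through (propyl in place of hydrogen on a nitrogen on an aromatic ring). For the measured compounds named here, no measured step touches this nitrogen; the one step known, an at least 6.2-fold lower number from compound 2 to compound 3 (0.79 log units; beyond the scatter), concerns a methyl on a ring carbon and so does not bear directly on it. With nothing to point either way, compound 4 is expected to stay close to compound 3, giving no change at the digits printed from compound 3 to compound 4 (within the scatter). The estimate for compound 4 in this assay is therefore 4000 nM, within 1300 nM to 12000 nM.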

Compound 4, half-maximal cytotoxic concentration: > 25000 nM
Compound 4 was reported as a limit; the forecaster's own chance of this, stated with the estimate: 20%; at least 6.2-fold (0.79 log units) between middle value and limit.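

Among the compounds shown here, on a nitrogen on an aromatic ring, a place no earlier step touched, propyl in place of hydrogen gave an at least 6.2-fold higher number from compound 3 to compound 4 (0.79 log units; beyond the scatter), which shows that this position also moves the read-out in this assay, and in the opposite direction to the earlier change on an aromatic carbon, even though compound 4 keeps that methyl. Compound 4 gives > 25000 nM, which is a limit of the test and not a number, so the step fixes only a minimum size for the change. Compound 3 is now the only compound in the set with a number, the others sitting at one limit: the limit of > 25000 nM in this assay, at which 3 of the 4 values shown sit.

The compounds shown leave open whether a shorter chain such as ethyl, a longer chain such as butyl, or a ring such as cyclopropyl on this nitrogen would also reach the limit. Going by these compounds, it also stays open whether a hydroxyl or a carboxylic acid on the propyl chain would preserve the result.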